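The source may hold more compounds than are shown below. What is called first, only, known or untested is meant among the compounds shown, and "the series" means these compounds.

Compound 1 `COc1cc(CNC(=O)CC(c2ccccc2)c2ccccc2)cc(OC)c1` was examined in an assay on CHO cells for displacement of a labelled ligand from Substance-P receptor (Homo sapiens) (on this read-out higher numbers stand for weaker inhibition and lower numbers for stronger inhibition), where compound 1 gives 2240 nM. Compound 2 `COc1cc(CN(C)C(=O)CC(c2ccccc2)c2ccccc2)cc(OC)c1` differs from it at a single place: methyl in place of hydrogen on an amide-type nitrogen. In this assay compound 2 gives 226 nM, and the step that this change made is a 9.9-fold lower number from compound 1 to compound 2 (1.00 log units; beyond the scatter). Compound 3 `O=C(CC(c1ccccc1)c1ccccc1)NCc1cc(Cl)cc(Cl)c1` carries a different core; the difference between the core of compound 1 and the core of compound 3 is not broken down here. In this assay compound 3 gives 226 nM, a number level with that of compound 2 at the digits reported and within the scatter of it, while compound 1 sits at a higher number than either of them.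

Compound 4 `CN(Cc1cc(Cl)cc(Cl)c1)C(=O)CC(c1ccccc1)c1ccccc1` has not yet been measured. It stands to compound 3 exactly as compound 2 stands to compound 1: methyl in place of hydrogen on an amide-type nitrogen. The place of this change is described in the same words for both pairs, so it is the same change, made this time on the core of compound 3 rather than on the core of compound 1. Because the measured step came out as a 9.9-fold lower number from compound 1 to compound 2 (1.00 log units; beyond the scatter), the same change on compound 3 is expected to make a step of about a 9.0-fold lower number from compound 3 to compound 4 (0.96 log units; beyond the scatter). Among the measured compounds shown here, that expectation rests on one measured pair alone, with no second example of the change on another core, so it carries some uncertainty. On this basis compound 4 is expected to give about 25 nM in this assay, with a span from 8 nM to 80 nM regarded as likely.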

Compound 4, half-maximal inhibitory concentration: 45 nM
Compound 4: middle estimate off by 1.8-fold (0.26 log units), on the low side; measured number inside the range.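

Across the core of compound 3, methyl in place of hydrogen on the amide-type nitrogen gave a 5.0-fold lower number from compound 3 to compound 4 (0.70 log units; beyond the scatter) in this assay, so the number fell again when the change was carried to a second core. Set side by side, the two steps point the same way and their sizes cannot be told apart: the same change on two cores in this assay, a 9.9-fold lower number (1.00 log units; beyond the scatter) from compound 1 to compound 2 and a 5.0-fold lower number (0.70 log units; beyond the scatter) from compound 3 to compound 4, 2.0-fold (0.30 log units) apart, within the scatter of two such steps. This shows that the change carried over between the core of compound 1 and the core of compound 3, but it rests on these two pairs alone, so it does not show that the change would carry to any other core, and it says nothing about why the number falls.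

The compounds shown leave open how far the substituent on the amide-type nitrogen can be taken, since an ethyl group, a longer chain or a chain ending in an amine or a carboxylic acid does not appear among them. They also leave open whether the step would hold on a core carrying a nitrile or a trifluoromethyl group in place of the chlorines of compound 3, or on a core with one of the two phenyl groups replaced.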